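Ring Size Swap at the Aminopyridine Nitrogen Substituent

The compounds below may be only part of what the source reports. "The series", "measured", "known", "first", "only" and "open" are said of these compounds alone.

Compound 1: `CCCN(CCC)c1nc(C(F)(F)F)ccc1CNC(=O)C(C)c1ccc(NS(C)(=O)=O)c(F)c1`, 0.2 nM
Compound 2: `COC1CCN(c2nc(C(F)(F)F)ccc2CNC(=O)C(C)c2ccc(NS(C)(=O)=O)c(F)c2)CC1`, 2.4 nM

Of the compounds shown here, two have been measured in a functional assay on CHO-K1 cells for antagonist activity at transient receptor potential cation channel subfamily V member 1 (Homo sapiens), read by FLIPR; a lower number here means a stronger inhibitor, a higher number a weaker inhibitor. Compound 2 gives 2.4 nM, the highest of the two numbers; its nearest neighbour is compound 1, and a 12-fold higher number from compound 1 to compound 2 (1.08 log units; beyond the scatter). Compound 3 `CC(C(=O)NCc1ccc(C(F)(F)F)nc1N1CCCCCCC1)c1ccc(NS(C)(=O)=O)c(F)c1` is not yet measured. It differs from compound 2 in a single place: a group of 8 heavy atoms (7 carbon, 1 nitrogen; one eight-membered non-aromatic ring with 1 hetero atom) in place of a group of 8 heavy atoms (6 carbon, 1 nitrogen, 1 oxygen; one six-membered non-aromatic ring with 1 hetero atom), on an aromatic carbon. For the measured compounds named here, the only step that bears on this position is the one from compound 1 to compound 2, where a dipropylamino group gave way to the methoxy-substituted ring and the number rose by a large margin. Compound 3 carries a ring made only of carbon and a single nitrogen, which resembles the dipropylamino group of compound 1 more than the methoxy-bearing ring of compound 2. The expectation is therefore a step back toward lower numbers, a 4.0-fold lower number from compound 2 to compound 3 (0.60 log units; beyond the scatter). Compound 3 is estimated at 0.6 nM, with a range from 0.15 nM to 2.5 nM.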

Compound 3, inhibition constant: 0.7 nM
Compound 3: the middle estimate sits 1.2-fold (0.07 log units) below what was measured; low and high end bracket the measured number.
By their numbers in this assay, from the lowest: compound 1; then compound 3; then compound 2.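

In this assay, exchanging the 4-methoxypiperidin-1-yl group for the eight-membered ring, with the same count of heavy atoms, gives a 3.4-fold lower number from compound 2 to compound 3 (0.54 log units; beyond the scatter), so a ring on this aromatic carbon is compatible with a low number and does not by itself carry the full rise seen with compound 2. The ring still does not match the open dipropylamino group, with a 3.5-fold higher number from compound 1 to compound 3 (0.54 log units; beyond the scatter), which leaves compound 1 with the lowest number of the three. Nothing available explains either step.

The compounds shown leave open whether the lower number of compound 3 goes with the larger ring or with the loss of the methoxy group, since both differ from compound 2. From the compounds shown here alone, a plain piperidin-1-yl group would separate these two changes, and how diethylamino compares with dipropylamino also stays open.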